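Working notes: replacing 4-methylphenyl on the carbonyl carbon

This account rests on a few compounds, and the source may have more. Where it says the series, first, only, none or still open, it means among the compounds named here.

Compound 1 `C=C(Br)C(=O)Nc1ccc(/C=C/C(=O)c2ccc(F)cc2)cc1` in a functional assay on L1210 cells (Mus musculus) for antiproliferative activity, with a stated time of 48 h (a higher number here means a weaker inhibitor, a lower number a stronger inhibitor), gives 1600 nM here
Compound 2 `C=C(Br)C(=O)Nc1ccc(/C=C/C(=O)c2ccc(I)cc2)cc1` gives 3400 nM here
Compound 3 `C=C(Br)C(=O)Nc1ccc(/C=C/C(=O)c2ccc(C)cc2)cc1` gives 1900 nM here

Compound 3 lies within the scatter of both other compounds, as a 1.2-fold higher number from compound 1 to compound 3 (0.07 log units; within the scatter) and a 1.8-fold lower number from compound 2 to compound 3 (0.25 log units; within the scatter) show for this assay here. Among the measured compounds shown here, compound 4 `C=C(Br)C(=O)Nc1ccc(/C=C/C(=O)c2cccs2)cc1` has thiophen-2-yl in place of 4-methylphenyl on a carbonyl carbon and no measured step covers this exchange. The nearest evidence is the exchange of groups on an aromatic carbon, where the largest change, a 2.1-fold higher number from compound 1 to compound 2 (0.33 log units; beyond the scatter) in size, is modest. No step beyond the scatter is therefore expected in this assay here. The expected step is a 1.1-fold lower number from compound 3 to compound 4 (0.02 log units; within the scatter) on this estimate. Compound 4 is expected near 1800 nM with an estimated range from 900 nM to 3600 nM in this assay.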

Compound 4, half-maximal inhibitory concentration: 250 nM
Compound 4: middle estimate off by 7.2-fold (0.86 log units), on the high side; the whole stated range lies above it.
By their numbers in this assay, from the lowest: compound 4; then compounds 1, 3 and 2 (each within the scatter of the next, the first and the last beyond it).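

In this assay, the group on the carbonyl carbon proves far more sensitive to replacing the whole ring than to exchanging groups on an aromatic carbon, where the largest change was a 2.1-fold higher number from compound 1 to compound 2 (0.33 log units; beyond the scatter). Thiophen-2-yl gives a 7.6-fold lower number from compound 3 to compound 4 (0.88 log units; beyond the scatter), a 6.4-fold lower number from compound 1 to compound 4 (0.81 log units; beyond the scatter) and a 14-fold lower number from compound 2 to compound 4 (1.13 log units; beyond the scatter), making compound 4 the strongest inhibitor of the four. No evidence at hand accounts for this difference.

As far as these compounds go, whether the difference follows the sulfur atom or the five-membered ring remains open. A furan-2-yl or an unsubstituted phenyl on the carbonyl carbon would help to separate the two.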